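The source may report more compounds than this note shows. Statements on the series, on what has been measured and on what is new or still open speak of the compounds shown alone.

The series shares one core, seen in compound 1 `COc1cccc(Nc2nc3nonc3nc2Nc2cccc(OC)c2)c1`, compound 2 `CCc1ccc(Nc2nc3nonc3nc2Nc2ccc(CC)cc2)cc1` and compound 3 `Fc1ccccc1Nc1nc2nonc2nc1NCCC(F)(F)F`. In an assay on mitochondria from L6 cells (Rattus norvegicus) for activation, with a stated time of 90 min (on this read-out lower numbers stand for an effect already at smaller amounts and higher numbers for an effect only at larger amounts of compound), compound 2 gives 3900 nM. Compound 1 reaches only the limit of this assay, > 100000 nM. Compound 3 likewise reaches only a limit in this assay, > 100000 nM. Compound 3 thus stands at the limit of > 100000 nM in this assay, at which 2 of the 3 values shown sit, with no number of its own. Compound 4 `Cc1ccccc1Nc1nc2nonc2nc1Nc1ccccc1F` differs from compound 3 by 2-methylphenyl in place of 3,3,3-trifluoropropyl on a nitrogen on an aromatic ring. With that change compound 4 carries two aryl-bearing nitrogens on the core, as compound 1 and compound 2 do, and those two span from a number to a limit. A step beyond the scatter in this assay, towards an effect at smaller amounts, is expected from compound 3 to compound 4, an at least 5.0-fold lower number from compound 3 to compound 4 (0.69 log units; beyond the scatter). Compound 4 is expected at 20000 nM, within 3000 nM to 100000 nM.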

Compound 4, half-maximal effective concentration: 1100 nM
Estimate against measurement, compound 4: 18-fold (1.26 log units) above; the whole stated range lies above it.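

In this assay, within the data shown here, 2-methylphenyl in place of 3,3,3-trifluoropropyl on a nitrogen on an aromatic ring gives an at least 90-fold lower number from compound 3 to compound 4 (1.95 log units; beyond the scatter), the first single-place comparison, and it shows that this position responds strongly to the change. The step holds for this pair only. Compound 1 also carries two aryl-bearing nitrogens and reaches only a limit, > 100000 nM.

Still open, on these data alone, is how a benzyl group, a cyclohexyl group or a longer alkyl chain would read at this nitrogen. The true size of the step also stays open, as compound 3 has no number of its own: the limit of > 100000 nM in this assay, at which 2 of the 4 values shown sit.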